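Swapping methoxymethyl for 1-hydroxypropyl on a shared core

The source may report more compounds than this note shows. Statements on the series, on what has been measured and on what is new or still open speak of the compounds shown alone.

Compound 1 `CC(=O)OCCO[C@H](CC=C(C)C)C1=CC(=O)c2c(O)ccc(O)c2C1=O` gives 41500 nM in the test below
Compound 2 `COCCO[C@H](CC=C(C)C)C1=CC(=O)c2c(O)ccc(O)c2C1=O` gives 62400 nM in the same test

Both compounds were measured in a functional assay on HeLa cells (Homo sapiens) for cytotoxicity, read by MTT assay (on this read-out lower numbers stand for stronger inhibition and higher numbers for weaker inhibition), and stand level with each other. The step of a 1.5-fold higher number from compound 1 to compound 2 (0.18 log units; within the scatter) is all that separates them, so compound 2 cannot be told apart from compound 1. Compound 3 `CCC(O)CO[C@H](CC=C(C)C)C1=CC(=O)c2c(O)ccc(O)c2C1=O` keeps the shared core, and 1-hydroxypropyl replaces methoxymethyl on a saturated chain carbon bound to an oxygen on a saturated carbon (1-hydroxypropyl in place of methoxymethyl on a saturated chain carbon bound to an oxygen on a saturated carbon). Within the data shown here, the one measured step, acetyl to methyl (a 1.5-fold higher number from compound 1 to compound 2 (0.18 log units; within the scatter)), also falls on this side chain and stayed within the scatter. Among the measured compounds shown here, it is a single step and a different change, and no measured compound carries a hydroxyl on this chain, so the evidence is thin. No step beyond the scatter is therefore expected in this assay here. The expected size is (a 1.2-fold lower number from compound 2 to compound 3 (0.10 log units; within the scatter)). Compound 3 is estimated at 50000 nM with an expected range from 24000 nM to 100000 nM in this test.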

Compound 3, half-maximal inhibitory concentration: 28700 nM
Compound 3: middle estimate off by 1.7-fold (0.24 log units), on the high side, within the range that was stated.
By their numbers in this assay, from the lowest: compounds 3, 1 and 2 (each within the scatter of the next, the first and the last beyond it).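

In this assay this side chain gives its first step beyond the scatter: 1-hydroxypropyl in place of methoxymethyl brings (a 2.2-fold lower number from compound 2 to compound 3 (0.34 log units; beyond the scatter)), a modest change that shows the position is not wholly indifferent to the group it carries. Against the acetoxymethyl group of compound 1, the same 1-hydroxypropyl brings only (a 1.4-fold lower number from compound 1 to compound 3 (0.16 log units; within the scatter)), so compound 3 and compound 1 cannot be told apart, and the new group does not stand clear of both earlier ones. No measurement shown here accounts for the step.

1-hydroxypropyl differs from methoxymethyl both in its hydrogen-bond donor and in its heavy atoms, and these compounds do not separate the two. An amine or a carboxylic acid in place of 1-hydroxypropyl, or a longer chain that keeps the hydroxyl, remains an open test.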